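One stereocentre drawn: what compound 3 may show

The source may hold more compounds than are shown below. What is called first, only, known or untested is meant among the compounds shown, and "the series" means these compounds.

Values in a functional assay on MCF7 cells (Homo sapiens) for cytotoxicity, read by sulforhodamine B assay (a higher number here means that more compound is needed for the effect, a lower number that less compound is needed), for the two measured compounds:
- compound 1 `O=C1CC(c2ccccc2)Nc2ccccc21` gives 0.13 ug/mL
- compound 2 `COc1cccc(C2CC(=O)c3ccccc3N2)c1` gives 0.32 ug/mL

Compound 2 holds the higher of the two numbers, so more of it is needed for the effect. The step behind this is a 2.5-fold higher number from compound 1 to compound 2 (0.39 log units; beyond the scatter) and it is the only one measured. Compound 3 `COc1cccc([C@@H]2CC(=O)c3ccccc3N2)c1` comes from compound 2 by a different kind of change (the two compounds have the same atoms and bonds; at least one stereo element is drawn with a configuration in one of them and without one in the other: 1 of 1 stereo elements differ; a stereocentre at a saturated ring carbon is drawn without a configuration in compound 2 and S in compound 3) and has not yet been measured. Within the data shown here, the single measured step swapped a hydrogen for methoxy, so it gives no direct size for a change in how a stereocentre is drawn. Among the measured compounds shown here, no measured pair here tests such a change. The expectation therefore stays close to compound 2 at 0.32 ug/mL and no step beyond the scatter is expected in this assay in either direction, while the range is kept wide. The expected step is a 1.1-fold lower number from compound 2 to compound 3 (0.03 log units; within the scatter) as an estimate only. For compound 3 the estimated value is 0.3 ug/mL with an expected range from 0.12 ug/mL to 0.9 ug/mL in this measurement.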

Compound 3, concentration for half-maximal effect: 0.3 ug/mL
Compound 3: middle estimate and measured number agree at the digits printed; measured number inside the range.
By their numbers in this assay, from the lowest: compound 1; then compounds 3 and 2 (each within the scatter of the next).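

Among these compounds, until now, the only measured change in this assay was a methoxy in place of hydrogen on an aromatic carbon, which said nothing about the stereocentre at the saturated ring carbon. The new pair tests that carbon directly, and the step is a 1.1-fold lower number from compound 2 to compound 3 (0.03 log units; within the scatter), so the numbers for the compound drawn without a configuration and the one drawn as S cannot be told apart in this assay. Among the compounds shown here, this is a first reading for this kind of change, and it rests on a single pair whose only difference is how that one carbon is drawn: the fact that one of compounds 2 and 3 is drawn with a defined configuration and the other without, at the place where they differ.

As far as these compounds go, a drawing without a configuration does not reveal which forms a sample contains, so it remains open how the R form at this carbon would read and whether the two mirror-image forms would give similar numbers. Also open is whether the same result would hold with another group in place of the methoxy, such as an amine or a carboxylic acid, since the compounds shown test the stereocentre with methoxy alone.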